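The source may hold more compounds than are shown below. What is called first, only, known or untested is meant among the compounds shown, and "the series" means these compounds.

Measured so far, in a functional assay on EL4 cells (Mus musculus) for inhibition, tested at 100 uM; a higher number here means more inhibition at the concentration tested (going by the name of the read-out), a lower number less inhibition:

Compound 1 `[O-][n+]1ccc2c(c1)ncn2[C@H]1C[C@H](O)[C@@H](CO)O1` gives < 5% in this assay, a limit rather than a number.
Compound 2 `CCCCCCNc1[nH]ccc2ncnc1-2` gives 100% in this assay.

Going by the values given here, compound 2 thus stands at the only full number in the set; the other value is a limit of < 5% in this assay, at which 1 of the 2 values shown sits, and no step between the two can be sized. Compound 1 and compound 2 share no single-point difference, so the pair shows only that one sits at the limit and the other at a higher number.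

Compound 3 `OCCNc1[nH]ccc2ncnc1-2` differs from compound 2 in one place: hydroxy in place of butyl on a saturated chain carbon, two bonds along the chain from a nitrogen on an aromatic ring. With no measured step of this kind in the set, the size of the step is open. Hexyl to hydroxyethyl is a large replacement, and a lower number than that of compound 2 is expected, though the read-out of compound 2 leaves room for the value to stay high. The step from compound 2 to compound 3 is estimated at a number 45 percentage points lower from compound 2 to compound 3 (beyond the scatter). Compound 3 is expected to give about 55%, within 15% to 95%.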

Compound 3, a percentage reported as inhibition, at one concentration (the size of the read-out at that concentration, not a potency): < 5%
Compound 3: a limit, no number (the forecaster's own chance of this, stated with the estimate: 10%); middle value at least 50 percentage points from the limit.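

Going by these compounds alone, on the saturated chain carbon two bonds along from a nitrogen on an aromatic ring, hydroxy in place of butyl gives a number at least 95 percentage points lower from compound 2 to compound 3 (beyond the scatter), the first step whose size has a bound. As far as these compounds go, compound 3 gives < 5% in this assay, which is a limit and not a number, so the full size of the step stays unknown. The inhibition seen with compound 2 therefore does not hold for every chain at this place on the shared core, and the low end of the read-out now carries more of the series: the limit of < 5% in this assay, at which 2 of the 3 values shown sit.

This one change removes butyl and brings in hydroxy together, so the compounds shown do not separate the two. A plain ethyl chain would separate them, while a longer chain such as octyl, or an amine at the chain end, would show how far the read-out follows the chain.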